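Replacing dimethylcarbamoyl on compound 2

The source may report more compounds than this note shows. Statements on the series, on what has been measured and on what is new or still open speak of the compounds shown alone.

In a functional assay on CAL-51 cells (Homo sapiens) for antiproliferative activity, read by luminescence and CellTiter-Glo, with a stated time of 3 days (on this read-out higher numbers stand for weaker inhibition and lower numbers for stronger inhibition), compound 1 `COc1cc(C(=O)N(C)C)ccc1Nc1nc(OC2CCCCC2)c2cc[nH]c2n1` gives 190 nM and compound 2 `COc1cc(C(=O)N(C)C)ccc1Nc1nc(O[C@H]2CCOC(C)(C)C2)c2cc[nH]c2n1` gives 131 nM, so the two stand level. Compound 3 `COc1cc(N2CCN(C(=O)CO)CC2)ccc1Nc1nc(O[C@H]2CCOC(C)(C)C2)c2cc[nH]c2n1` carries 4-((hydroxymethyl)carbonyl)piperazin-1-yl in place of dimethylcarbamoyl on an aromatic carbon. Among the measured compounds shown here, the only measured step, a 1.5-fold lower number from compound 1 to compound 2 (0.16 log units; within the scatter), came with 2,2-dimethyloxan-4-yl in place of cyclohexyl and leaves the dimethylcarbamoyl group untouched, so it offers no direct guide. Compound 2 stands at 131 nM in this assay, and no shift beyond the scatter is therefore expected for compound 3. The estimated change is a 1.1-fold lower number from compound 2 to compound 3 (0.04 log units; within the scatter). For compound 3 the expected value is 120 nM, with an estimated range of 35 nM to 400 nM.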

Compound 3, half-maximal inhibitory concentration: 37 nM
Beside the measured number, compound 3's estimate is 3.2-fold (0.51 log units) above it; the range from low to high includes it.
By their numbers in this assay, from the lowest: compound 3; then compounds 2 and 1 (each within the scatter of the next).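

Among the compounds shown here, the aromatic carbon meta to a methoxy group accepts a larger group with a ring: in this assay the change to 4-((hydroxymethyl)carbonyl)piperazin-1-yl gives a 3.5-fold lower number from compound 2 to compound 3 (0.55 log units; beyond the scatter) and is the first step beyond the scatter. For the compounds shown here, the earlier step changed only the group on oxygen, so this is the first sign that this position affects the read-out. No data here explain the step.

Going by these compounds, it remains open whether the piperazine ring or the hydroxymethyl carbonyl end accounts for the change. A free piperazine amine or a carboxylic acid at this position would help separate the two.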